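Swapping Dimethoxy for Dichloro on the Aniline Nitrogen

The source may report more compounds than this note shows. Statements on the series, on what has been measured and on what is new or still open speak of the compounds shown alone.

Of the compounds shown here, three sharing one core have been measured so far in a functional assay on DU-145 cells (Homo sapiens) for cytotoxicity, read by MTT assay, with a stated time of 48 h; a lower number here means a stronger inhibitor, a higher number a weaker inhibitor. Compound 3 `COc1ccc(N/C(CCNC2=CC(=O)c3ccccc3C2=O)=N\S(=O)(=O)c2ccc(C)cc2)c(OC)c1` stands at the weak end: in this assay compound 3 gives 67300 nM, while compound 1 `Cc1ccc(S(=O)(=O)/N=C(/CCNC2=CC(=O)c3ccccc3C2=O)Nc2ccc(Cl)cc2)cc1` gives 32400 nM and compound 2 `Cc1ccc(S(=O)(=O)/N=C(/CCNC2=CC(=O)c3ccccc3C2=O)Nc2ccc(F)c(F)c2)cc1` gives 12900 nM. Both gaps to compound 3 are modest but beyond the scatter: a 2.1-fold higher number from compound 1 to compound 3 (0.32 log units; beyond the scatter) and a 5.2-fold higher number from compound 2 to compound 3 (0.72 log units; beyond the scatter). Between the two halogenated rings themselves there is also a modest difference, a 2.5-fold lower number from compound 1 to compound 2 (0.40 log units; beyond the scatter).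

Compound 4 `Cc1ccc(S(=O)(=O)/N=C(/CCNC2=CC(=O)c3ccccc3C2=O)Nc2ccc(Cl)cc2Cl)cc1` differs from compound 3 in a single place: 2,4-dichlorophenyl in place of 2,4-dimethoxyphenyl on an amine nitrogen. Going by the values given here, two measured steps bear on this change, since each of them sets the 2,4-dimethoxyphenyl against a ring carrying halogens, and both of those rings gave lower numbers than compound 3. The change to compound 4 likewise replaces the 2,4-dimethoxyphenyl with a ring carrying two chlorines, so a lower number than compound 3 is expected, most likely landing in the span between compound 1 and compound 2. Compound 4 is therefore estimated at 20000 nM, with a likely range from 6000 nM to 60000 nM. This estimate amounts to an expected step of a 3.4-fold lower number from compound 3 to compound 4 (0.53 log units; beyond the scatter).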

Compound 4, half-maximal inhibitory concentration: 18600 nM
For compound 4 the middle estimate is 1.1-fold (0.03 log units) above the measured one; the range from low to high includes it.
By their numbers in this assay, from the lowest: compounds 2, 4 and 1 (each within the scatter of the next, the first and the last beyond it); then compound 3.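

In this assay the pattern on the ring is held as 2,4-dichlorophenyl takes the place of 2,4-dimethoxyphenyl, so only the kind of group changes, and this alone gives a clear step (a 3.6-fold lower number from compound 3 to compound 4 (0.56 log units; beyond the scatter)). Going by these compounds alone, the earlier comparisons with compound 3 each changed the pattern as well, so this is the first sign that the weaker number of compound 3 goes with its methoxy groups rather than with the pattern alone. The other two steps show no readable difference among the halogenated rings (a 1.4-fold higher number from compound 2 to compound 4 (0.16 log units; within the scatter); a 1.7-fold lower number from compound 1 to compound 4 (0.24 log units; within the scatter)), so adding a chloro to the ring of compound 1 changes nothing that can be read here, and the 2,4-dichlorophenyl of compound 4 cannot be told apart from the 3,4-difluorophenyl of compound 2; no measurement at hand explains any of these results.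

The compounds shown leave open whether a single methoxy, as in a 4-methoxyphenyl ring, would already give a number like that of compound 3. They also leave open where a plain phenyl ring, or one carrying a nitrile or a trifluoromethyl, would fall on the same amine nitrogen.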